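The source may hold more compounds than are shown below. What is called first, only, known or untested is meant among the compounds shown, and "the series" means these compounds.

Compound 2 `NCCCNc1c(C(=O)NCc2ccc(F)cc2)nc(Br)c2cccnc12` was tested in a functional assay on MDA-MB-435 cells (Homo sapiens) for cytotoxicity, read by MTT assay, with a stated time of 72 h (on this read-out lower numbers stand for stronger inhibition and higher numbers for weaker inhibition), where compound 2 gives 5000 nM. Compound 1 `N[C@H]1CC[C@H](Nc2c(C(=O)NCc3ccc(F)cc3)nc(N3CCCCS3(=O)=O)c3cccnc23)CC1` gives 5000 nM in this assay, and compound 2 stands level with it within the scatter of the measurement. Compound 3 `C[C@H](CO)Nc1nc(C(=O)NCc2ccc(F)cc2)c(O)c2ncccc12` sits at the limit of > 20000 nM in this assay, at which 1 of the 3 values shown sits: in this assay compound 3 gives > 20000 nM, which is a limit of the assay rather than a number. Compound 4 `NCCCCCCNc1c(C(=O)NCc2ccc(F)cc2)nc(Br)c2cccnc12` has not yet been measured. It differs from compound 2 in one place: 3-aminopropyl in place of amino on a saturated chain carbon, three bonds along the chain from a nitrogen on an aromatic ring. Among the measured compounds shown here, no measured pair shows a change of this kind, so the step is expected to stay within the scatter, in either direction. The expected step of no change at the digits printed from compound 2 to compound 4 (within the scatter) is therefore none beyond the scatter. Compound 4 is expected to give about 5000 nM in this assay, with a likely range from 2000 nM to 15000 nM.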

Compound 4, half-maximal inhibitory concentration: 6000 nM
Estimate against measurement, compound 4: 1.2-fold (0.08 log units) below; measured number inside the range.
By their numbers in this assay, from the lowest: compounds 1, 2 and 4 (each within the scatter of the next). At a limit, above all of these: compound 3.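

In this assay, among the compounds shown here, the first measured step at this position, 3-aminopropyl to 6-aminohexyl on the chain, gives a 1.2-fold higher number from compound 2 to compound 4 (0.08 log units; within the scatter). This chain therefore takes the added carbons with no change that can be told from the scatter, though one pair shows no trend. Nothing measured here bears on why the number holds. The compounds shown leave open whether a shorter 2-aminoethyl chain would stay level. They also leave open what a carboxylic acid in place of the amino group would do.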